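Aryl sulfonyl swap from nitro to methoxy on the bare core

The source may report more compounds than this note shows. Statements on the series, on what has been measured and on what is new or still open speak of the compounds shown alone.

Compound 3 `C/C(=N\NC(N)=S)C1c2ccccc2CCN1S(=O)(=O)c1ccc([N+](=O)[O-])cc1` carries a nitrophenyl sulfonyl on the unsubstituted core. In a functional assay on HuCC-A1 cells (Homo sapiens) for cytotoxicity, read by crystal violet staining, with a stated time of 3 days (on this read-out higher numbers stand for weaker inhibition and lower numbers for stronger inhibition), compound 3 reaches only a limit, > 50 ug/mL. Its methyl analogue, compound 2 `C/C(=N\NC(N)=S)C1c2ccccc2CCN1S(=O)(=O)c1ccc(C)cc1`, likewise sits at a limit in this assay, > 50 ug/mL. The step that the two limits leave unreadable from compound 2 to compound 3 therefore cannot be sized: both values rest on (the limit of > 50 ug/mL in this assay, at which 2 of the 3 values shown sit). For the measured compounds named here, the one numbered value in the set belongs to compound 1 `COc1ccc(S(=O)(=O)N2CCc3cc(OC)c(OC)cc3C2/C(C)=N/NC(N)=S)cc1`, which combines a methoxyphenyl sulfonyl with a dimethoxy core and gives 31 ug/mL in this assay.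

Compound 4 `COc1ccc(S(=O)(=O)N2CCc3ccccc3C2/C(C)=N/NC(N)=S)cc1` is compound 3 with methoxy in place of nitro on an aromatic carbon. Going by the values given here, no measured step covers this exact exchange; the only step touching the sulfonyl aryl, from compound 2 to compound 3, is unreadable. Among the compounds with values here, compound 1 shows that a methoxyphenyl sulfonyl can give a readable value, but it differs from compound 4 also in the core, and no step for that pair exists. The expectation for compound 4 is thus weakly held, and the implied step a number no higher from compound 3 to compound 4 (the limit leaves the size open) is expected to stay near the limit. Compound 4 is estimated at 50 ug/mL in this assay, in a range from 20 ug/mL to 120 ug/mL.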

Compound 4, half-maximal inhibitory concentration: > 50 ug/mL
Compound 4: no number, only a limit; the forecaster's own chance of this, stated with the estimate: 55%; the middle value lies on the limit itself.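

No step can be read among compound 2, compound 3 and compound 4 in this assay, since all three sit at the same limit: the limit of > 50 ug/mL in this assay, at which 3 of the 4 values shown sit.

The compounds shown leave open how the methyl, nitro and methoxy aryl sulfonyl groups rank on the shared core, and whether the core of compound 1 is what goes with its 31 ug/mL.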